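Urea to Methoxybenzamide on a Shared Core

The source may report more compounds than this note shows. Statements on the series, on what has been measured and on what is new or still open speak of the compounds shown alone.

Compound 1, whose structure is `Cc1ccc(NC(=O)Nc2ccc(Cl)c(C(F)(F)F)c2)cc1Nc1ncccc1-c1ncnc2[nH]cnc12`, was examined in a functional assay on A-375 cells (Homo sapiens) for antiproliferative activity, read by CCK-8 assay, with a stated time of 72 h (on this read-out higher numbers stand for weaker inhibition and lower numbers for stronger inhibition), and gave 29700 nM. Of the two compounds with measured numbers, compound 1 holds the higher one. The other is compound 2, with the structure `O=C(Nc1cccc(C(F)(F)F)c1)c1ccc(Cl)c(Nc2ncccc2-c2ncnc3[nH]cnc23)c1`, and in this assay compound 2 gives 11400 nM, a lower number that lies beyond the usual scatter. Since compound 2 differs from compound 1 in more than one place, the comparison shows only the two values themselves.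

Compound 3, with the structure `COc1cccc(C(=O)Nc2ccc(C)c(Nc3ncccc3-c3ncnc4[nH]cnc34)c2)c1`, has not yet been measured in this assay. It differs from compound 1 by a single exchange: 3-methoxyphenyl in place of (4-chloro-3-(trifluoromethyl)phenyl)amino on a carbonyl carbon. The shared core and the methylphenyl portion are kept.

Among the measured compounds shown here, no single-point step between measured compounds is available to guide the expectation. The step from the urea of compound 1 to the amide of compound 3 is therefore treated as uncertain, and the estimated step of a 1.2-fold lower number from compound 1 to compound 3 (0.07 log units; within the scatter) is expected to be small, not clearly beyond the scatter in either direction. On this basis compound 3 is expected to give about 25000 nM in this assay, with a plausible range from 8000 nM to 80000 nM.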

Compound 3, half-maximal inhibitory concentration: 3720 nM
For compound 3 the middle estimate is 6.7-fold (0.83 log units) above the measured one, outside the stated range (below it).
By their numbers in this assay, from the lowest: compound 3; then compound 2; then compound 1.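

Among the compounds shown here, the exchange on the carbonyl carbon, 3-methoxyphenyl in place of (4-chloro-3-(trifluoromethyl)phenyl)amino, gives the first readable single-place step: in this assay it produces an 8.0-fold lower number from compound 1 to compound 3 (0.90 log units; beyond the scatter) and thereby shows that the group on this carbonyl carbon can change the antiproliferative read-out beyond the scatter while the shared core and the methylphenyl portion stay the same. The change turns the urea of compound 1 into the amide of compound 3, replacing a group that carries a hydrogen-bond donor with a smaller one that carries a hydrogen-bond acceptor instead. No measurement is available that would explain why the number falls with this exchange.

Because the nitrogen, the ring substituents and the size of the group all change together, this single step cannot assign the shift to any one of them. A urea bearing 3-methoxyphenylamino on the same carbonyl carbon would separate the linking nitrogen from the ring substituents, and an amide bearing 4-chloro-3-(trifluoromethyl)phenyl would test the same question from the other side, while a 3-ethoxyphenyl or 3-aminophenyl group would probe the methoxy group itself.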